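The compounds below may be only part of what the source reports. "The series", "measured", "known", "first", "only" and "open" are said of these compounds alone.

Measured so far in a functional assay on HepG2 cells (Homo sapiens) for antiproliferative activity, read by XTT assay, with a stated time of 72 h; a lower number here means a stronger inhibitor, a higher number a weaker inhibitor:
compound 1, `COc1ncnc2c1c(-c1ccoc1)cn2[C@@H]1O[C@H](CO)[C@@H](O)[C@H]1O`: 290 nM
compound 2, `Cc1ncnc2c1c(-c1ccoc1)cn2[C@@H]1O[C@H](CO)[C@@H](O)[C@H]1O`: 5320 nM

On the numbers shown, compound 1 stands lowest of the two; its nearest neighbour is compound 2, reached by an 18-fold higher number from compound 1 to compound 2 (1.26 log units; beyond the scatter), with methyl in place of methoxy on an aromatic carbon.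

Compound 3, `C#Cc1cn([C@@H]2O[C@H](CO)[C@@H](O)[C@H]2O)c2ncnc(OC)c12`, is not yet measured. It differs from compound 1 in ethynyl in place of furan-3-yl on an aromatic carbon. Among the compounds with values here, no measured step bears on this change: the single step seen concerns the methoxy group and leaves the furan-3-yl untouched, so nothing here tells how this assay responds to removing that ring or to the ethynyl that enters. The size of the step is therefore set without precedent, and a moderate rise in the number beyond the scatter is expected rather than a fall, with a wide range.

Compound 3 is expected to give 700 nM, between 150 nM and 3500 nM. The expected step is a 2.4-fold higher number from compound 1 to compound 3 (0.38 log units; beyond the scatter).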

Compound 3, half-maximal inhibitory concentration: 12700 nM
Estimate against measurement, compound 3: 18-fold (1.26 log units) below; measured number outside the range, above it.
By their numbers in this assay, from the lowest: compound 1; then compound 2; then compound 3.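

In this assay the carbon of the five-membered aromatic ring that carries furan-3-yl turns out to be sensitive: ethynyl in that place gives a 44-fold higher number from compound 1 to compound 3 (1.64 log units; beyond the scatter) and so leaves compound 3 well short of compound 1. Within the data shown here, this is the first measured change at that carbon, whereas the earlier step, an 18-fold higher number from compound 1 to compound 2 (1.26 log units; beyond the scatter), concerned only the methoxy group, so both places on the core of compound 1 now show a large response to a single change. Nothing measured here accounts for the rise at the furan-3-yl position.

The change removes the ring, goes from 5 heavy atoms to 2, drops the 1 hydrogen-bond acceptor and brings in a triple bond all at once, and these remain unseparated. Also open, going by these compounds, is how this assay would respond to a phenyl ring, a thiophene ring or a longer alkyne chain on this carbon.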